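Alkyne-linked aminopyrimidine series: vinyl to methyl on the pendant ring

The source may report more compounds than this note shows. Statements on the series, on what has been measured and on what is new or still open speak of the compounds shown alone.

Measured so far:
Compound 1, `C=CC(=O)NCC#Cc1ccc2ncn(-c3ccnc(N)n3)c2c1`, 6310 nM
Compound 2, `C=Cc1ccnc(C#Cc2ccc3ncn(-c4ccnc(N)n4)c3c2)n1`, 1580 nM

Both compounds share a core carrying a triple-bonded carbon; they differ in the group attached to it. In an assay on Sf9 cells for inhibition of mitogen-activated protein kinase kinase kinase 14 variant S549D (Homo sapiens), with a stated time of 30 min, in the presence of a further agent that is not named here (a lower number here means a stronger inhibitor, a higher number a weaker inhibitor), compound 1 gives 6310 nM, and compound 2 gives 1580 nM. Within the data shown here, the single step on record, a 4.0-fold lower number from compound 1 to compound 2 (0.60 log units; beyond the scatter), exchanges the whole group on the triple-bonded carbon. Among the measured compounds shown here, compound 2 therefore stands as the lowest of the two numbers, with compound 1 as its only neighbour.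

Compound 3, `Cc1ccnc(C#Cc2ccc3ncn(-c4ccnc(N)n4)c3c2)n1`, has not been measured. Against compound 2 the change is methyl in place of vinyl on an aromatic carbon. For the measured compounds named here, no measured step isolates this exchange: the only step recorded alters a larger group and carries a ring change with it, so it gives no direct reading on the size of a vinyl-to-methyl swap. On that footing no step beyond the scatter is anticipated in this assay, though the uncertainty is wide in both directions.

For compound 3 the estimate is 2500 nM, with a range of 900 nM to 8000 nM. The expected step, a 1.6-fold higher number from compound 2 to compound 3 (0.20 log units; within the scatter), is judged to fall within the scatter.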

Compound 3, half-maximal inhibitory concentration: 1580 nM
The estimate for compound 3 lay 1.6-fold (0.20 log units) above the measured number; low and high end bracket the measured number.
By their numbers in this assay, from the lowest: compounds 2 and 3 (each within the scatter of the next); then compound 1.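

In this assay the exchange of vinyl for methyl on the aromatic carbon next to the ring nitrogen gives no change at the digits printed from compound 2 to compound 3 (within the scatter), so the double bond outside the aromatic rings and the second carbon of vinyl are not required at this position for the number seen with compound 2. The methyl compound also keeps the difference from the open-chain amide, with a 4.0-fold lower number from compound 1 to compound 3 (0.60 log units; beyond the scatter), which shows that the lower number seen on placing the pendant ring on the triple-bonded carbon does not depend on vinyl being present. There is no supporting evidence that would explain either result.

Vinyl and methyl are small carbon groups, and neither carries a hydrogen-bond donor or acceptor, so the series shown does not say whether an amine, a carboxylic acid or a longer chain such as n-butyl on this carbon would move the number beyond the scatter. It also leaves open how much of the step from the open-chain amide comes from the ring nitrogens, a question that a phenyl ring on the triple-bonded carbon would address.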